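A few compounds are considered here, and "the series" means these few. Any claim that something is new, unique, unknown or untested is made for them only; others in the source may bear on it.

Compound 3 `COc1ccc2c(=O)c(/C=C/C(=O)Nc3cccc(C)c3)coc2c1` gives 15500 nM in a functional assay on Huh-7 cells (Homo sapiens) for inhibition, read by MTT assay, with a stated time of 48 h; a higher number here means a weaker inhibitor, a lower number a stronger inhibitor. Among the three compounds measured so far, compound 3 stands second highest. Compound 1 `COc1ccc2c(=O)c(/C=C/C(=O)NCc3ccccc3)coc2c1` gives 13600 nM, and the two lie close together, the step being a 1.1-fold higher number from compound 1 to compound 3 (0.06 log units; within the scatter), which falls within the scatter. Compound 2 `COc1ccc2c(=O)c(/C=C/C(=O)Nc3ccccc3OC)coc2c1` gives 32300 nM in this assay, and the step of a 2.1-fold lower number from compound 2 to compound 3 (0.32 log units; beyond the scatter) separates them, a modest difference. The remaining measured step is a 2.4-fold higher number from compound 1 to compound 2 (0.38 log units; beyond the scatter).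

Compound 4 `COc1ccc2c(=O)c(/C=C/C(=O)Nc3ccc(F)cc3)coc2c1` differs from compound 3 in one place: 4-fluorophenyl in place of 3-methylphenyl on an amide-type nitrogen. Among the measured compounds shown here, no measured step exchanges one substituted phenyl on the amide-type nitrogen for a fluorine-bearing one, so the guidance comes only from the two steps that change the group on that nitrogen, a 1.1-fold higher number from compound 1 to compound 3 (0.06 log units; within the scatter) and a 2.1-fold lower number from compound 2 to compound 3 (0.32 log units; beyond the scatter), both small. A step of a 1.0-fold lower number from compound 3 to compound 4 (0.01 log units; within the scatter) in this assay is therefore expected, not clearly beyond the scatter. Compound 4 is estimated at 15000 nM, within a range from 7000 nM to 35000 nM.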

Compound 4, half-maximal inhibitory concentration: 33900 nM
Beside the measured number, compound 4's estimate is 2.3-fold (0.35 log units) below it, within the range that was stated.
By their numbers in this assay, from the lowest: compounds 1 and 3 (each within the scatter of the next); then compounds 2 and 4 (each within the scatter of the next).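

In this assay the group on the amide-type nitrogen shifts the number even when one substituted phenyl replaces another: 4-fluorophenyl in place of 3-methylphenyl gives (a 2.2-fold higher number from compound 3 to compound 4 (0.34 log units; beyond the scatter)), and 4-fluorophenyl in place of benzyl gives (a 2.5-fold higher number from compound 1 to compound 4 (0.40 log units; beyond the scatter)). Against 2-methoxyphenyl the same group gives (a 1.0-fold higher number from compound 2 to compound 4 (0.02 log units; within the scatter)), so compounds 2 and 4 read alike, as compounds 1 and 3 do, and the four compounds fall into two pairs. Nothing available explains this division into pairs.

Going by these compounds, whether the step from 3-methylphenyl belongs to gaining the fluorine or to losing the methyl remains open, and a plain phenyl on that nitrogen would separate the two. A 3-fluorophenyl group would test the place of the fluorine, and a 2-phenylethyl group would extend the comparison with benzyl.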